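Swapping the ring on an amine nitrogen: compound 4

The source may report more compounds than this note shows. Statements on the series, on what has been measured and on what is new or still open speak of the compounds shown alone.

Compound 1 `CC#CC(CC(=O)O)c1ccc(OCc2ccc(C(=O)N3CCN(c4ccccc4)CC3)s2)cc1` gives 72 nM in a functional assay on HEK293 cells for agonist activity at Free fatty acid receptor 1 (Homo sapiens), read by fluorescence and calcium flux; on this read-out lower numbers stand for an effect already at smaller amounts and higher numbers for an effect only at larger amounts of compound.
Compound 2 `CC#CC(CC(=O)O)c1ccc(OCc2ccc(C(=O)N3CCN(Cc4ccccc4)CC3)s2)cc1` gives 155 nM.
Compound 3 `CC#CC(CC(=O)O)c1ccc(OCc2ccc(C(=O)N3CCN(c4cccnc4)CC3)s2)cc1` gives 1140 nM.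

Compound 3 stands highest of the three numbers in this assay: the step is a 7.4-fold higher number from compound 2 to compound 3 (0.87 log units; beyond the scatter) and a 16-fold higher number from compound 1 to compound 3 (1.20 log units; beyond the scatter). Compound 4 `CC#CC(CC(=O)O)c1ccc(OCc2ccc(C(=O)N3CCN(c4ccc([N+](=O)[O-])cc4)CC3)s2)cc1` differs from compound 3 in one place: 4-nitrophenyl in place of pyridin-3-yl on an amine nitrogen in a ring. Within the data shown here, the step that bears on this is the large one a 16-fold higher number from compound 1 to compound 3 (1.20 log units; beyond the scatter), which shows that replacing the ring of carbon only by pyridin-3-yl raised the number greatly; compound 4 returns to a ring of carbon only, now bearing a nitro group, for which no measured step exists. A drop is therefore expected, though perhaps not all the way back to compound 1, giving an estimated step of a 5.7-fold lower number from compound 3 to compound 4 (0.76 log units; beyond the scatter). Compound 4 is expected to give about 200 nM, between 60 nM and 700 nM.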

Compound 4, half-maximal effective concentration: 231 nM
The estimate for compound 4 lay 1.2-fold (0.06 log units) below the measured number; the range from low to high includes it.
By their numbers in this assay, from the lowest: compound 1; then compounds 2 and 4 (each within the scatter of the next); then compound 3.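

Putting nitro on the phenyl of compound 1 raises the number only modestly (a 3.2-fold higher number from compound 1 to compound 4 (0.51 log units; beyond the scatter)), so a ring of carbon only at this position keeps much of its effect even with this added group. The 4-nitrophenyl ring also gives a clear drop from pyridin-3-yl (a 4.9-fold lower number from compound 3 to compound 4 (0.69 log units; beyond the scatter)), while the step from benzyl (a 1.5-fold higher number from compound 2 to compound 4 (0.17 log units; within the scatter)) stays within the scatter. No measured evidence here explains these steps. From the compounds shown here alone, whether an amine or a methoxy group in the place of nitro would give a similar number remains open.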